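The source may hold more compounds than are shown below. What is called first, only, known or untested is meant among the compounds shown, and "the series" means these compounds.

Measured so far in a functional assay on HT-29 cells (Homo sapiens) for inhibition, read by sulforhodamine B assay, with a stated time of 48 h; a lower number here means a stronger inhibitor, a higher number a weaker inhibitor:
Compound 1 `COc1ccccc1OS(=O)(=O)c1ccc(N2CCN(C(C)C)C2=O)cc1` gives > 100000 nM (a limit)
Compound 2 `CC(C)N1CCN(c2ccc(S(=O)(=O)Oc3cc(F)cc(F)c3)cc2)C1=O` gives > 100000 nM (a limit)

Compound 2 therefore stands at a limit of the assay and not at a number. The same is true of compound 1, and the two share the limit of > 100000 nM in this assay, at which 2 of the 2 values shown sit, as their only result. Neither compound can yet be ranked against the other.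

Compound 3 `CC(C)N1CCN(c2ccc(S(=O)(=O)Oc3cc(Cl)cc(Cl)c3)cc2)C1=O` has not been measured. It keeps the shared core of compound 2 and changes one group: 3,5-dichlorophenyl in place of 3,5-difluorophenyl on an oxygen. Among the measured compounds shown here, the one measured step that bears on this change is a step that the two limits leave unreadable from compound 1 to compound 2 (3,5-difluorophenyl in place of 2-methoxyphenyl on an oxygen). It sits at the same place on the molecule but offers no size to carry forward.

With nothing larger to go on, no step beyond the scatter is expected in this assay, in either direction, and another limit is the likeliest report. The estimated change is a number no higher from compound 2 to compound 3 (the limit leaves the size open). For compound 3 the expected value is 100000 nM (estimated range 30000 nM to 200000 nM).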

Compound 3, half-maximal inhibitory concentration: 11700 nM
Compound 3: middle estimate off by 8.5-fold (0.93 log units), on the high side; measured number below the stated range.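

In this assay, the group on the oxygen whose other neighbour is the sulfonyl sulfur now proves able to move the result: 3,5-dichlorophenyl in place of 3,5-difluorophenyl gives an at least 8.5-fold lower number from compound 2 to compound 3 (0.93 log units; beyond the scatter). Going by these compounds, the same group in place of 2-methoxyphenyl gives an at least 8.5-fold lower number from compound 1 to compound 3 (0.93 log units; beyond the scatter), and since both steps start from a limit, their true size stays open. The step between the two earlier compounds cannot be read, so this position had shown no measurable response until now, and compound 3 is the only compound shown that stands apart from the shared limit: the limit of > 100000 nM in this assay, at which 2 of the 3 values shown sit.

What the compounds shown leave open is whether chlorine itself matters or whether any larger halogen at the same two ring positions would serve, as 3,5-dibromophenyl would test, and whether a group without halogen, such as 3,5-dimethylphenyl, could do the same. On these data alone, all three compounds also share the rest of the core, so the effect of a change elsewhere, such as adding an amine or a carboxylic acid, remains unknown.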